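The source may report more compounds than this note shows. Statements on the series, on what has been measured and on what is new or still open speak of the compounds shown alone.

Going by the values given here, compound 3 `O=C(NN=C1CC(c2ccccc2)NC(c2ccccc2)C1)c1ccc(Cl)cc1` is one of three compounds measured in a functional assay on A549 cells (Homo sapiens) for cytotoxicity, read by MTT assay, with a stated time of 24 h; a higher number here means a weaker inhibitor, a lower number a stronger inhibitor. For compound 3 the result in this assay is only a limit, > 400000 nM. Compound 1 `CCOC(=O)N1CCC(=NNC(=O)c2ccc(Cl)cc2)CC1` also reaches only a limit in this assay, > 400000 nM. Compound 2 `CCOC(=O)N1CCC(=NNC(=O)c2ccc(C(F)(F)F)cc2)CC1` gives a number in this assay, 37100000 nM. The step that the limit leaves unreadable from compound 1 to compound 2 cannot be sized, because the limit of > 400000 nM in this assay, at which 2 of the 3 values shown sit, hides where compound 1 actually lies. Compound 4 `O=C(NN=C1CC(c2ccccc2)NC(c2ccccc2)C1)c1ccc(C(F)(F)F)cc1` differs from compound 3 by trifluoromethyl in place of chloro on an aromatic carbon, the same change as that between compound 1 and compound 2. Among the compounds with values here, that single measured step is the only guide, and it yields no size. The values of compound 1 and compound 2 show merely that compound 2 gives a number at a weak level of inhibition, which points to a weak inhibitor for compound 4 as well. Compound 4 is therefore expected to give about 20000000 nM in this assay, somewhere between 400000 nM and 100000000 nM. The expected step that the limit leaves unreadable from compound 3 to compound 4 is estimated only loosely, and a limit is the likely outcome.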

Compound 4, half-maximal inhibitory concentration: > 400000 nM
Compound 4 was reported as a limit; the forecaster's own chance of this, stated with the estimate: 60%; the middle value is on the limit's open side.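

In this assay compound 4 gives > 400000 nM as a limit only. Compound 3 likewise gives > 400000 nM as a limit only. Going by these compounds alone, no step from compound 3 to compound 4 can be read: the limit of > 400000 nM in this assay, at which 3 of the 4 values shown sit. The compounds shown leave open where compound 3 and compound 4 actually lie, and whether trifluoromethyl in place of chloro changes the result in this pair.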